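This account rests on a few compounds, and the source may have more. Where it says the series, first, only, none or still open, it means among the compounds named here.

Series notes. Compound 1 `CC1(C)[C@@H](CO)CC[C@@]1(C)Cn1cc(I)c(=O)[nH]c1=O` carries iodo on the shared core; compound 2 `CC1(C)[C@@H](CO)CC[C@@]1(C)Cn1ccc(=O)[nH]c1=O` differs by hydrogen in place of iodo on an aromatic carbon. In an ADME assay on L1210/0 cells (Mus musculus) for cytotoxicity, with a stated time of 48 h (on this read-out higher numbers stand for weaker inhibition and lower numbers for stronger inhibition), compound 1 gives only a limit, > 200000 nM. In this assay compound 2 likewise gives only a limit, > 200000 nM. The step that the two limits leave unreadable from compound 1 to compound 2 therefore cannot be read, because the limit of > 200000 nM in this assay, at which 3 of the 3 values shown sit, caps both ends. Compound 3 `O=c1[nH]c(=O)n([C@@H]2C[C@H](CO)C[C@@H]2CO)cc1I` has a different core; the difference between the two cores is not broken down here. In this assay compound 3 gives only a limit, > 200000 nM. Compound 4 `O=c1ccn([C@@H]2C[C@H](CO)C[C@@H]2CO)c(=O)[nH]1` is the unmeasured partner of compound 3, differing by hydrogen in place of iodo on an aromatic carbon. The place lines differ in one detail: meta to a large group in the first pair, meta to a group of 9 heavy atoms here, so this is the same kind of change, not the same. Since all three values sit at the limit of > 200000 nM in this assay, at which 3 of the 3 values shown sit, compound 4 is expected to return a limit as well, with an estimated step that the limit leaves unreadable from compound 3 to compound 4. Compound 4 is estimated at 300000 nM, between 100000 nM and 1000000 nM.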

Compound 4, half-maximal inhibitory concentration: > 200000 nM
Compound 4: only a limit was reported; the forecaster's own chance of this, stated with the estimate: 90%; the middle value lies beyond the limit too.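

No step can be read between compound 3 and compound 4, because both ends are capped: the limit of > 200000 nM in this assay, at which 4 of the 4 values shown sit. The compounds shown leave open whether iodo or hydrogen on the aromatic carbon makes any difference in this assay, on either core.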